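This account rests on a few compounds, and the source may have more. Where it says the series, first, only, none or still open, it means among the compounds named here.

Measured so far:
compound 1, `c1cc(NC2=NCCO2)cc(OC2CCCC2)c1` — 52200 nM
compound 2, `c1cc(NC2=NCCO2)cc(OC2CCCCC2)c1` — 4400 nM
compound 3, `O=C(CCl)NC(=O)Nc1ccc(OC2CCCC2)cc1` — 3100 nM

These values come from a functional assay on HT-29 cells (Homo sapiens) for inhibition, read by sulforhodamine B assay, with a stated time of 48 h; on this read-out higher numbers stand for weaker inhibition of growth and lower numbers for stronger inhibition of growth. Compound 1 and compound 2 share a core and differ by cyclohexyl in place of cyclopentyl on an oxygen on an aromatic ring; this change gave a 12-fold lower number from compound 1 to compound 2 (1.07 log units; beyond the scatter). Compound 3 has a different core; the difference between the two cores is not broken down here. Compound 4, `O=C(CCl)NC(=O)Nc1ccc(OC2CCCCC2)cc1`, is not yet measured. It relates to compound 3 by cyclohexyl in place of cyclopentyl on an oxygen on an aromatic ring, the same change as between compound 1 and compound 2, at the same place. The step from compound 3 to compound 4 in this assay is expected to be smaller than the earlier one, because a 12-fold lower number from compound 1 to compound 2 (1.07 log units; beyond the scatter) was seen on a different core and a single example gives no assurance of the same size elsewhere. The expected step is a 3.9-fold lower number from compound 3 to compound 4 (0.59 log units; beyond the scatter). Compound 4 is estimated at 800 nM, with a range from 200 nM to 3000 nM.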

Compound 4, concentration for 50% growth inhibition: 3100 nM
Beside the measured number, compound 4's estimate is 3.9-fold (0.59 log units) below it; measured number above the stated range.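

In this assay, placing cyclohexyl instead of cyclopentyl on the oxygen gave no change at the digits printed from compound 3 to compound 4 (within the scatter). The size of this change's effect therefore did not carry over from one core to the other: the same change on two cores in this assay, a 12-fold lower number (1.07 log units; beyond the scatter) from compound 1 to compound 2 and no change at the digits printed (within the scatter) from compound 3 to compound 4, 12-fold (1.07 log units) apart, beyond the scatter of two such steps This shows that the effect of the swap depends on the core in these two pairs, but it does not show why, and two cores give no rule for predicting a third.

The compounds shown leave open how either core responds to a cycloheptyl ring or an open butyl chain on that oxygen. They also leave open whether the difference between the two cores holds in other cell lines.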